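Acetamido in place of hydroxy: notes toward compound 3

The source may report more compounds than this note shows. Statements on the series, on what has been measured and on what is new or still open speak of the compounds shown alone.

Measured so far in a functional assay on MCF7 cells (Homo sapiens) for cytotoxicity, read by sulforhodamine B assay, with a stated time of 72 h; a higher number here means a weaker inhibitor, a lower number a stronger inhibitor:
compound 1 `O=C1C=C(OCc2cn([C@@H]3O[C@H](CO)[C@@H](O)[C@H](O)[C@H]3O)nn2)C(=O)c2ccccc21` gives 38900 nM.
compound 2 `O=C1C=C(OCc2cn([C@@H]3O[C@H](CO)[C@H](O)[C@H](O)[C@H]3O)nn2)C(=O)c2ccccc21` gives > 50000 nM, which is a limit of the assay and not a number.

For the measured compounds named here, compound 1 holds the only number in the set. The value of compound 2 is a limit. Compound 1 and compound 2 differ only in configuration as drawn, and the step of an at least 1.2-fold higher number from compound 1 to compound 2 (0.10 log units; that floor lies within the scatter). Compound 3 `CC(=O)N[C@@H]1[C@@H](O)[C@H](O)[C@@H](CO)O[C@H]1n1cc(COC2=CC(=O)c3ccccc3C2=O)nn1` carries acetamido in place of hydroxy on a saturated ring carbon. Going by the values given here, no measured step touches this change, so the single measured step gives no guide; the expectation for compound 3 rests on compound 1 alone. Compound 3 is estimated at 40000 nM, between 15000 nM and 100000 nM. The step of a 1.0-fold higher number from compound 1 to compound 3 (0.01 log units; within the scatter) is expected to stay within the scatter.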

Compound 3, half-maximal inhibitory concentration: > 50000 nM
Compound 3: a limit, no number; the forecaster's own chance of this, stated with the estimate: 40%; middle value at least 1.2-fold (0.09 log units) from the limit.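

In this assay compound 3 gives > 50000 nM, which is a limit of the assay and not a number. Replacing hydroxy with acetamido on this saturated ring carbon gives an at least 1.2-fold higher number from compound 1 to compound 3 (0.10 log units; that floor lies within the scatter), so this change brings no measurable cytotoxicity. Its true size cannot be read, because the series sits against the top of the measurable range: the limit of > 50000 nM in this assay, at which 2 of the 3 values shown sit.

Going by these compounds, it remains open whether an amine or a methoxy group on this ring carbon would give a number in this assay. On these data alone, the effect of a longer acyl chain in place of acetamido also remains open.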